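Amino in Place of Chloro Tried on a Second Core

This account rests on a few compounds, and the source may have more. Where it says the series, first, only, none or still open, it means among the compounds named here.

Measured in a functional assay on MCF7 cells (Homo sapiens) for cytotoxicity, read by sulforhodamine B assay, with a stated time of 48 h; on this read-out higher numbers stand for lower toxicity in this test and lower numbers for higher toxicity in this test:
Compound 1 `ClCc1ccccc1Cn1cnc2c(Cl)nc(Cl)nc21` gives > 100000 nM, which is a limit of the test.
Compound 2 `ClCc1cccc(Cn2cnc3c(Cl)nc(Cl)nc32)c1` gives > 100000 nM, also a limit of the test.
Compound 3 `Nc1nc(Cl)c2ncn(Cc3ccccc3CCl)c2n1` gives 87100 nM.

Compound 1 and compound 2 are built from the same atoms joined differently; the difference between the two cores is not broken down here. From compound 1 to compound 3 the change is amino in place of chloro on an aromatic carbon, and in this assay it produced an at least 1.1-fold lower number from compound 1 to compound 3 (0.05 log units; that floor lies within the scatter). The two limits sit at the same level (the limit of > 100000 nM in this assay, at which 2 of the 3 values shown sit).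

Compound 4 `Nc1nc(Cl)c2ncn(Cc3cccc(CCl)c3)c2n1` is not yet measured. It differs from compound 2 by amino in place of chloro on an aromatic carbon, the same change at a place described in the same words. Because the earlier step of an at least 1.1-fold lower number from compound 1 to compound 3 (0.05 log units; that floor lies within the scatter) stayed within the scatter, the step to compound 4 is expected to be an at least 1.1-fold lower number from compound 2 to compound 4 (0.04 log units; that floor lies within the scatter) in this assay. Compound 4 is therefore estimated at about 90000 nM, between 40000 nM and 300000 nM, with a good chance that this assay again reports only a limit.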

Compound 4, concentration lethal to 50% of the cells: 53700 nM
Beside the measured number, compound 4's estimate is 1.7-fold (0.22 log units) above it, within the range that was stated.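

In this assay, amino in place of chloro on an aromatic carbon of the core of compound 2 gave an at least 1.8-fold lower number from compound 2 to compound 4 (0.27 log units; that floor lies within the scatter). Set beside the same change on the core of compound 1, this step shows that the change can be carried to the second core without a result that contradicts the first, although neither floor goes beyond the scatter: the same change on two cores in this assay, an at least 1.1-fold lower number (0.05 log units; that floor lies within the scatter) from compound 1 to compound 3 and an at least 1.8-fold lower number (0.27 log units; that floor lies within the scatter) from compound 2 to compound 4; the limit leaves it open whether they differ. It does not show that the size of the step carries over, because compound 1 and compound 2 both stand at a limit of the test, so neither step has a known size: the limit of > 100000 nM in this assay, at which 2 of the 4 values shown sit.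

The compounds shown leave open whether a group other than amino at this place, such as a methoxy group or a dimethylamine, would shift the number in this test. They also leave open whether the change would give steps of similar size on a core whose starting compound has a measured value rather than a limit.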